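Nitro for Cyano on Two Related Cores

A few compounds are considered here, and "the series" means these few. Any claim that something is new, unique, unknown or untested is made for them only; others in the source may bear on it.

Three compounds have been measured in a functional assay on VCaP cells (Homo sapiens) for antiproliferative activity, read by propidium iodide staining, with a stated time of 96 h; on this read-out higher numbers stand for weaker inhibition and lower numbers for stronger inhibition:
compound 1 `CC(O)(CSc1cccc(S(F)(F)(F)(F)F)c1)C(=O)Nc1ccc(C#N)c(C(F)(F)F)c1` gives 31700 nM
compound 2 `CC(O)(CSc1cccc(S(F)(F)(F)(F)F)c1)C(=O)Nc1ccc([N+](=O)[O-])c(C(F)(F)F)c1` gives 9800 nM
compound 3 `CC(O)(CSc1ccc(S(F)(F)(F)(F)F)cc1)C(=O)Nc1ccc(C#N)cc1C(F)(F)F` gives 20500 nM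

Compound 1 and compound 2 share one core; compound 3 and the still unmeasured compound 4 `CC(O)(CSc1ccc(S(F)(F)(F)(F)F)cc1)C(=O)Nc1ccc([N+](=O)[O-])cc1C(F)(F)F` share another, and the difference between the two cores is not broken down here. Compound 2 differs from compound 1 by nitro in place of cyano on an aromatic carbon, and that step gave a 3.2-fold lower number from compound 1 to compound 2 (0.51 log units; beyond the scatter). Compound 4 differs from compound 3 by nitro in place of cyano on an aromatic carbon. This is the same kind of change, not the same: in compound 1 the changed carbon is ortho to a trifluoromethyl group, in compound 3 it is meta to a trifluoromethyl group. Among the measured compounds shown here, since the only measured instance of this change is a 3.2-fold lower number from compound 1 to compound 2 (0.51 log units; beyond the scatter), a step of similar size is expected, a 3.2-fold lower number from compound 3 to compound 4 (0.50 log units; beyond the scatter). Compound 4 is therefore estimated at 6500 nM in this assay, with a likely range from 2500 nM to 16000 nM.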

Compound 4, half-maximal inhibitory concentration: 26300 nM
Estimate against measurement, compound 4: 4.0-fold (0.61 log units) below; the whole stated range lies below it.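

On the core of compound 3, nitro in place of cyano gave no difference that can be told from the scatter in this assay, with a 1.3-fold higher number from compound 3 to compound 4 (0.11 log units; within the scatter). The lower number seen on the core of compound 1 therefore did not carry over, and the two steps disagree: the same change on two cores in this assay, a 3.2-fold lower number (0.51 log units; beyond the scatter) from compound 1 to compound 2 and a 1.3-fold higher number (0.11 log units; within the scatter) from compound 3 to compound 4, 4.1-fold (0.62 log units) apart, beyond the scatter of two such steps. This shows that the size of this change cannot simply be moved from one core to the other in this series, but two pairs do not show which feature of the cores sets the outcome, or what would happen on a further core.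

No pair shown breaks down the difference between the two cores. As far as these compounds go, how a carboxylic acid or an amine on that aromatic carbon would compare with cyano and nitro also remains open.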